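The source may hold more compounds than are shown below. What is called first, only, known or untested is meant among the compounds shown, and "the series" means these compounds.

Compound 1 `c1ccc(-c2cnoc2)c(NCC2=NCCN2)c1` carries, on its shared core, a 1,2-oxazol-4-yl group. In a functional assay for activation of Alpha-1B adrenergic receptor (Homo sapiens), read by calcium flux (a lower number here means that less compound is needed, a higher number that more compound is needed for the effect), compound 1 gives only a limit, < 100000 nM. Compound 2 `Cc1cccnc1-c1ccccc1NCC1=NCCN1` is a close relative of compound 1; in this assay compound 2 also gives only a limit, < 100000 nM. Compound 3 `Nc1nccc(-c2ccccc2NCC2=NCCN2)n1` is a further relative; in this assay compound 3 gives a limit too, < 5020 nM. Thus compound 1 stands at the limit of < 100000 nM in this assay, at which 2 of the 3 values shown sit, while one value sits at the limit of < 5020 nM in this assay, at which 1 of the 3 values shown sits; no number is known for any of the three, and no step between them can be sized.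

Compound 4 `CO/N=C(\C)c1ccccc1NCC1=NCCN1` differs from compound 1 by a group of 5 heavy atoms (3 carbon, 1 nitrogen, 1 oxygen; no ring) in place of a group of 5 heavy atoms (3 carbon, 1 nitrogen, 1 oxygen; one five-membered aromatic ring with 2 hetero atoms), on an aromatic carbon. With only limits to go on, no direction for this step can be read from the measured compounds; the step from compound 1 to compound 4 is expected to be a step that the limit leaves unreadable from compound 1 to compound 4, counted from the limit. Compound 4 is estimated at 3000 nM in this assay, with a range from 300 nM to 30000 nM.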

Compound 4, half-maximal effective concentration: < 5020 nM
Compound 4: only a limit was reported; the forecaster's own chance of this, stated with the estimate: 50%; the middle value lies beyond the limit too.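

Compound 1 and compound 4 are both known in this assay only as limits, so the step between them cannot be read. The compounds shown leave open where any of them truly stands, and whether replacing the 1,2-oxazol-4-yl group changes the concentration needed.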